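Replacing phenyl with 1H-imidazol-2-yl in a cytotoxic series

The source may hold more compounds than are shown below. What is called first, only, known or untested is meant among the compounds shown, and "the series" means these compounds.

Values measured in a functional assay on P388 cells (Mus musculus) for cytotoxicity; on this read-out lower numbers stand for stronger inhibition and higher numbers for weaker inhibition:
- compound 1 `Cc1cc(-c2c(F)cc3c(=O)c(Cc4ccc(Cl)cc4)cn(C4CC4)c3c2F)cc(C)n1` gives 20000 nM
- compound 2 `COc1ccccc1Cc1cn(C2CC2)c2c(F)c(-c3cc(C)nc(C)c3)c(F)cc2c1=O` gives 37000 nM
- compound 3 `Cc1cc(-c2c(F)cc3c(=O)c(Cc4ccccc4)cn(C4CC4)c3c2F)cc(C)n1` gives 7300 nM

Compound 3 holds the lowest number of the three. Compound 4 `Cc1cc(-c2c(F)cc3c(=O)c(Cc4ncc[nH]4)cn(C4CC4)c3c2F)cc(C)n1` differs from it as follows: 1H-imidazol-2-yl in place of phenyl on a saturated chain carbon bound to an aromatic carbon. In short, 1H-imidazol-2-yl stands in place of phenyl on a saturated chain carbon bound to an aromatic carbon. Going by the values given here, no measured step exchanges the ring itself, so the evidence is indirect. Two modest steps concern groups on the phenyl: a 2.7-fold lower number from compound 1 to compound 3 (0.44 log units; beyond the scatter) and a 5.1-fold lower number from compound 2 to compound 3 (0.70 log units; beyond the scatter). Both favour the plain phenyl, so a modest rise is tentatively expected in this assay. The expected change is a 2.1-fold higher number from compound 3 to compound 4 (0.31 log units; beyond the scatter). Compound 4 is estimated at 15000 nM, with an expected range of 4000 nM to 60000 nM.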

Compound 4, half-maximal inhibitory concentration: 1100 nM
The estimate for compound 4 lay 14-fold (1.13 log units) above the measured number; measured number below the stated range.
By their numbers in this assay, from the lowest: compound 4; then compound 3; then compounds 1 and 2 (each within the scatter of the next).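

In this assay, going by these compounds alone, the earlier steps changed only groups on the phenyl, whereas exchanging the ring itself for 1H-imidazol-2-yl gives a 6.6-fold lower number from compound 3 to compound 4 (0.82 log units; beyond the scatter) at this saturated chain carbon. The same exchange gives an 18-fold lower number from compound 1 to compound 4 (1.26 log units; beyond the scatter) and a 34-fold lower number from compound 2 to compound 4 (1.53 log units; beyond the scatter), so among these compounds a phenyl ring is not required for the lowest number. Nothing measured here explains the drop. The compounds shown leave open whether the gain depends on the ring nitrogens or the ring hydrogen. A pyridyl ring or a simple amine on this carbon would help separate these possibilities.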